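The source may report more compounds than this note shows. Statements on the series, on what has been measured and on what is new or still open speak of the compounds shown alone.

Measured so far:
compound 1, `CCCCCc1ccc(NC(=O)N[C@H](C)c2ccccc2)cc1`: 97%
compound 2, `CCCCCc1ccc(NC(=O)N[C@@H](C)c2ccccc2)cc1`: 93%

Both were run in an ADME assay on the whole organism with Oryza sativa as the target, tested at 10 uM; a higher number here means a weaker effect of the compound at the concentration tested, a lower number a stronger effect. Compound 1 gives 97%, the higher of the two numbers, with compound 2 nearest at 93%; the step of a number 4 percentage points lower from compound 1 to compound 2 (within the scatter) is within the scatter, which is consistent with the fact that compounds 1 and 2 differ only in the configuration as drawn. The two configurations at the chain carbon are therefore not distinguished in this assay.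

Compound 3, `C[C@@H](NC(=O)Nc1ccc(I)cc1)c1ccccc1`, has not been measured. Relative to compound 1 the change is iodo in place of pentyl on an aromatic carbon. Going by the values given here, the only measured step, a number 4 percentage points lower from compound 1 to compound 2 (within the scatter), concerns configuration alone and says nothing about the group on the aromatic ring, so no direction can be read from the data for this exchange. Compound 3 is expected at 85%, range 55% to 100%. This corresponds to an estimated step of a number 12 percentage points lower from compound 1 to compound 3 (beyond the scatter). Among the compounds with values here, the range is kept wide: no measured step speaks to the exchanged group.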

Compound 3, a percentage reported as activity, at one concentration (the size of the read-out at that concentration, not a potency): 85%
For compound 3 middle estimate and measured number coincide at the digits printed; the measured number falls inside the stated range.
By their numbers in this assay, from the lowest: compounds 3, 2 and 1 (each within the scatter of the next, the first and the last beyond it).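

In this assay, going by these compounds alone, the exchange of pentyl for iodo on the aromatic carbon gives a number 12 percentage points lower from compound 1 to compound 3 (beyond the scatter) and is the first step to lie beyond the scatter. This position therefore responds to the group it carries, whereas the configuration at the chain carbon gave no readable difference between compounds 1 and 2. Nothing available bears on why this exchange moves the number.

From the compounds shown here alone, whether the step belongs to iodo itself or to the loss of pentyl stays open, and a chloro, a methoxy, an amine or a carboxylic acid at the same place would help separate the two. Also open, going by these compounds, is whether the configuration at the chain carbon remains without readable effect when iodo stands on the ring.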